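The compounds below may be only part of what the source reports. "The series", "measured", "known", "first", "only" and "open" are said of these compounds alone.

Compound 1, `CCCCCCCCCCCC(=O)N[C@H](CCC(=O)NC1CCCCNC1=O)C(=O)O`: 1.73 nM
Compound 2, `CCCCCCCCCCCC(=O)N[C@H](CCC(=O)N[C@H](CCCCN)C(=O)O)C(=O)O`: > 100 nM

In a functional assay on HEK293 cells for agonist activity at Nucleotide-binding oligomerization domain-containing protein 1 (Homo sapiens), read by spectrophotometry (a higher number here means that more compound is needed for the effect, a lower number that less compound is needed), compound 1 gives 1.73 nM. For compound 2 this assay reports only a limit, > 100 nM, and no exact number (the limit of > 100 nM in this assay, at which 1 of the 2 values shown sits). Going by the values given here, the single step measured so far, an at least 57-fold higher number from compound 1 to compound 2 (1.76 log units; beyond the scatter), shows that putting 5-amino-1-carboxypentyl in place of 2-oxoazepan-3-yl on the amide-type nitrogen weakens the effect strongly. Compound 3, `CCCCCCCCCCCC(=O)N[C@H](CCC(=O)NCCCC[C@H](N)C(=O)O)C(=O)O`, has not been measured yet. It keeps the same atoms as compound 2 but joins them differently: 5-amino-5-carboxypentyl in place of 5-amino-1-carboxypentyl on an amide-type nitrogen. Among the compounds with values here, no measured step covers a rearrangement of this kind, and because compound 2 sits at a limit of > 100 nM in this assay, at which 1 of the 2 values shown sits, the true size of the earlier step is unknown. The direction of the step to compound 3 therefore cannot be read from the numbers shown. Compound 3 is expected at roughly 150 nM, between 10 nM and 3000 nM. That estimate means a step that the limit leaves unreadable from compound 2 to compound 3.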

Compound 3, half-maximal effective concentration: 0.96 nM
For compound 3 the middle estimate is 160-fold (2.19 log units) above the measured one, and the stated range ends above it.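

Joined one way, a set of atoms on the amide-type nitrogen gives a far weaker result than the same atoms joined another way: 5-amino-5-carboxypentyl in place of 5-amino-1-carboxypentyl gives an at least 100-fold lower number from compound 2 to compound 3 (2.01 log units; beyond the scatter), so at this position the arrangement of the atoms counts, not just which atoms are present. With a 1.8-fold lower number from compound 1 to compound 3 (0.26 log units; within the scatter), 5-amino-5-carboxypentyl and 2-oxoazepan-3-yl cannot be told apart here, which shows that an open chain can match 2-oxoazepan-3-yl on this nitrogen. Compound 2 carries a limit and not a number, so the full size of its gap remains unknown: the limit of > 100 nM in this assay, at which 1 of the 3 values shown sits.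

Still open, going by these compounds, is what a shorter or longer chain would do at this nitrogen. Equally open, on these data alone, is whether an ester in place of the carboxylic acid, or a hydroxyl in place of the amine, would keep the effect of compound 3.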